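The source may hold more compounds than are shown below. What is called first, only, known or untested is meant among the compounds shown, and "the series" means these compounds.

In a functional assay on CLL cells (Homo sapiens) for cytotoxicity, read by MTT assay, with a stated time of 48 h (on this read-out higher numbers stand for an effect only at larger amounts of compound and lower numbers for an effect already at smaller amounts), the measured compounds stand as follows:

compound 1 `C=C(CC)C(=O)c1ccc(OCC(=O)Nc2ccc(C(=O)O)cn2)c(Cl)c1Cl` gives 14900 nM
compound 2 `C=C(CC)C(=O)c1ccc(OCC(=O)Nc2ccc(C(C)=O)cc2)c(Cl)c1Cl` gives 3900 nM
compound 3 `C=C(CC)C(=O)c1ccc(OCC(=O)Nc2ccc(C(=O)OC)cc2)c(Cl)c1Cl` gives 4100 nM

Compound 3, at 4100 nM in this assay, lies within the scatter of compound 2, while compound 1 carries the higher number of the set.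

The next change leads to compound 4 `C=C(CC)C(=O)c1ccc(OCC(=O)Nc2ccc(C(N)=O)cc2)c(Cl)c1Cl`, with amino in place of methoxy on a carbonyl carbon, or methoxycarbonyl to carbamoyl (amino in place of methoxy on a carbonyl carbon). The nearest guide is the exchange at that same carbonyl carbon (a 1.1-fold higher number from compound 2 to compound 3 (0.02 log units; within the scatter)), where methoxy replaced methyl and the number stayed within the scatter. For the measured compounds named here, the only step beyond the scatter (a 3.8-fold lower number from compound 1 to compound 2 (0.58 log units; beyond the scatter)) is a much wider exchange on the amide-type nitrogen, so it says little about this single replacement, though it shows that the number can move with changes in that part of the molecule. Going by the values given here, no measured compound yet carries the amino group, so the direction is poorly defined. A small step is expected, probably within the scatter, with a slight lean towards a higher number. The expected step is (a 1.3-fold higher number from compound 3 to compound 4 (0.13 log units; within the scatter)). For compound 4 the estimated value is 5500 nM with an expected range from 2200 nM to 14000 nM in this assay.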

Compound 4, half-maximal effective concentration: 3700 nM
Beside the measured number, compound 4's estimate is 1.5-fold (0.17 log units) above it; the measured number falls inside the stated range.
By their numbers in this assay, from the lowest: compounds 4, 2 and 3 (each within the scatter of the next); then compound 1.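

In this assay, amino in place of methoxy on the carbonyl carbon gives a 1.1-fold lower number from compound 3 to compound 4 (0.04 log units; within the scatter), and amino in place of methyl at the same carbon gives a 1.1-fold lower number from compound 2 to compound 4 (0.02 log units; within the scatter), so this read-out does not separate methyl, methoxy and amino on a carbonyl carbon whose other neighbour is an aromatic carbon. The wider exchange on the amide-type nitrogen, 4-carbamoylphenyl in place of 5-carboxypyridin-2-yl, gives a 4.0-fold lower number from compound 1 to compound 4 (0.60 log units; beyond the scatter), which stands beyond the scatter and sits alongside the earlier 3.8-fold lower number from compound 1 to compound 2 (0.58 log units; beyond the scatter), so among these compounds only the step away from compound 1 moves the number beyond the scatter. No supporting measurement is available to explain either the flat behaviour at the carbonyl carbon or the separation of compound 1.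

Compound 1 differs from the others in both its ring and its end group, so the shift away from it cannot be assigned to the carboxy group or to the pyridinyl ring alone. Going by these compounds, it also remains open whether the flat behaviour extends to a nitrile, a primary amine or an N-methylcarbamoyl group on the same ring, or whether one of these would move the number beyond the scatter.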